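The compounds below may be only part of what the source reports. "The series", "measured", "known", "first", "only" and "open" are said of these compounds alone.

Of the compounds shown here, two built on one shared core have been tested in a functional assay on MCF7 cells (Homo sapiens) for antiproliferative activity, read by MTT assay, with a stated time of 48 h; on this read-out higher numbers stand for weaker inhibition and lower numbers for stronger inhibition. Compound 1 `Cc1cccc(-n2nncc2CN2C(=O)C3(C(C#N)=C(N)Oc4c(N)cc5nc6ccccc6nc5c43)c3ccccc32)c1` yields no number there. In this assay compound 1 gives only the assay limit > 50000 nM. For the measured compounds named here, compound 2 `COc1ccccc1-n1nncc1CN1C(=O)C2(C(C#N)=C(N)Oc3c(N)cc4nc5ccccc5nc4c32)c2ccccc21` carries a 2-methoxyphenyl on an aromatic nitrogen where compound 1 carries a 3-methylphenyl, and in this assay compound 2 gives 28900 nM, the only number among the two values. Going by the values given here, the step of an at least 1.7-fold lower number from compound 1 to compound 2 (0.23 log units; that floor lies within the scatter) is the sole measured step, and its true size is open since one of the two values sits at the limit of > 50000 nM in this assay, at which 1 of the 2 values shown sits. Compound 3 `CCOc1ccccc1-n1nncc1CN1C(=O)C2(C(C#N)=C(N)Oc3c(N)cc4nc5ccccc5nc4c32)c2ccccc21` differs from compound 2 by methyl in place of hydrogen on a saturated chain carbon bound to an oxygen on an aromatic ring, a change on a saturated chain carbon bound to an oxygen on an aromatic ring, which read one bond further out is methoxy to ethoxy. Among the compounds with values here, the only measured step, an at least 1.7-fold lower number from compound 1 to compound 2 (0.23 log units; that floor lies within the scatter), alters a different part of compound 2 and is itself of uncertain size, so the data give no reason to expect movement beyond the scatter. The step of a 1.0-fold higher number from compound 2 to compound 3 (0.02 log units; within the scatter) is therefore expected to be small. Compound 3 is estimated at 30000 nM, with a range from 10000 nM to 90000 nM, and a limit rather than a number is possible.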

Compound 3, half-maximal inhibitory concentration: > 50000 nM
Compound 3: only a limit was reported; the forecaster's own chance of this, stated with the estimate: 35%; middle value at least 1.6-fold (0.22 log units) away from the limit.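

At the saturated chain carbon bound to an oxygen on an aromatic ring, methyl in place of hydrogen, which turns 2-methoxyphenyl into 2-ethoxyphenyl, gives an at least 1.7-fold higher number from compound 2 to compound 3 (0.23 log units; that floor lies within the scatter) in this assay. For the compounds shown here, this is the first reading at this position, and it points only one way: compound 3 reports a limit of the assay and not a number, so the added methyl brings no measurable gain over the methoxy group, while the true size of the step stays unknown and its floor cannot be told apart from the scatter. Compound 2 remains the only one of the three with a number, and the step between compound 1 and compound 3 cannot be read, with both of them resting on the same limit: the limit of > 50000 nM in this assay, at which 2 of the 3 values shown sit.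

The compounds shown leave open how large the loss from methoxy to ethoxy really is, and whether any real difference separates the 2-ethoxyphenyl and 3-methylphenyl groups. On these data alone, whether a longer chain such as propoxy, or an amine in place of the methoxy, would give a number in this assay also stays open.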